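Removing One Chlorine From the Anilide of Compound 1

This account rests on a few compounds, and the source may have more. Where it says the series, first, only, none or still open, it means among the compounds named here.

Of the compounds shown here, three of a shared benzamide-to-ortho-aminoanilide type have been measured in a functional assay on U-251 cells (Homo sapiens) for inhibition, read by MTT assay, with a stated time of 2 days; on this read-out lower numbers stand for stronger inhibition of growth and higher numbers for weaker inhibition of growth. Compound 1 `Nc1ccccc1NC(=O)CCCNCC(=O)Nc1cc(Cl)ccc1Cl` gives 44000 nM. Compound 2 `COc1ccc(NC(=O)CNc2ccc(C(=O)Nc3ccccc3N)cc2)cc1` gives 25500 nM, and compound 3 `Cc1ccc(NC(=O)CNc2ccc(C(=O)Nc3ccccc3N)cc2)cc1` gives 84000 nM. On these three numbers compound 1 stands second highest; its gap to compound 2 and its gap to compound 3 both lie within the usual scatter, so no order among them can be claimed. Within the data shown here, the only single-place comparison available is a 3.3-fold higher number from compound 2 to compound 3 (0.52 log units; beyond the scatter), a modest change on the outer aryl amide of compounds 2 and 3.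

Compound 4 `Nc1ccccc1NC(=O)CCCNCC(=O)Nc1ccc(Cl)cc1` has not yet been measured. It differs from compound 1 in one place: 4-chlorophenyl in place of 2,5-dichlorophenyl on an amide-type nitrogen. Among the measured compounds shown here, no measured pair shows this particular change, and the one step that exists concerns a methyl for a methoxy on a different scaffold, so it offers only a sense of how far a single change on the outer aryl amide can move this read-out. On that basis the expectation for compound 4 is a step of a 1.1-fold higher number from compound 1 to compound 4 (0.06 log units; within the scatter) in this assay, not clearly beyond the scatter in either direction. Compound 4 is therefore estimated at 50000 nM, within a range from 15000 nM to 160000 nM.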

Compound 4, concentration for 50% growth inhibition: 11400 nM
The estimate for compound 4 lay 4.4-fold (0.64 log units) above the measured number, outside the stated range (below it).
By their numbers in this assay, from the lowest: compound 4; then compounds 2, 1 and 3 (each within the scatter of the next, the first and the last beyond it).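

In this assay, the aryl group on the amide-type nitrogen of compound 1 proves able to move the read-out: 4-chlorophenyl in place of 2,5-dichlorophenyl gives a 3.9-fold lower number from compound 1 to compound 4 (0.59 log units; beyond the scatter), a step beyond the scatter. Among these compounds, until now, the only such step was the methyl for methoxy change between compound 2 and compound 3, so this is the first on the compounds with the chain of compound 1, and it shows that fewer chlorines on this ring need not give a higher number. The group names also show that this is more than the loss of one chlorine, since the single chlorine of 4-chlorophenyl carries a number absent from 2,5-dichlorophenyl, and nothing given here explains the step.

The compounds shown leave open whether the step follows from the number of chlorines or from where they stand, a question that 2-chlorophenyl, 3-chlorophenyl or unsubstituted phenyl on the same amide-type nitrogen would bear on. They also leave open whether 4-methoxyphenyl or 4-methylphenyl would change the number on this chain, and whether a longer chain would alter the step.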